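Amide aryl groups in the series: toward compound 4

The source may report more compounds than this note shows. Statements on the series, on what has been measured and on what is new or still open speak of the compounds shown alone.

Measured in an in vitro ADME assay on microsomes from liver (Homo sapiens) for pharmacokinetics, read by LC-MS, with a stated time of 10 min, tested at 1 uM; a higher number here means faster removal of the compound, a lower number slower removal:
- compound 1 `CN1C[C@H](C(=O)Nc2ccc(Br)cc2)[C@@H](c2ccc(/C=C/C(=O)Nc3ccccc3N)cc2)C1` gives 3 mL/min/kg
- compound 2 `Cc1cccc(NC(=O)[C@H]2CN(C)C[C@@H]2c2ccc(/C=C/C(=O)Nc3ccccc3N)cc2)c1` gives 14 mL/min/kg
- compound 3 `COc1cccc(NC(=O)[C@H]2CN(C)C[C@@H]2c2ccc(/C=C/C(=O)Nc3ccccc3N)cc2)c1` gives 14 mL/min/kg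

Compound 3 stands level with compound 2 at the top of these three numbers, and compound 1 is the lowest. The next change, (2,4-difluorophenyl in place of 3-methoxyphenyl on an amide-type nitrogen), puts 2,4-difluorophenyl in place of 3-methoxyphenyl on an amide-type nitrogen and gives compound 4 `CN1C[C@H](C(=O)Nc2ccc(F)cc2F)[C@@H](c2ccc(/C=C/C(=O)Nc3ccccc3N)cc2)C1`, which is not yet measured.

Two measured steps change the group at this same place. Putting 3-methylphenyl in place of 4-bromophenyl gives a 4.7-fold higher number from compound 1 to compound 2 (0.67 log units; beyond the scatter), and putting 3-methoxyphenyl there gives a 4.7-fold higher number from compound 1 to compound 3 (0.67 log units; beyond the scatter). Both are modest and beyond the scatter. Methoxy in place of methyl gives no change at the digits printed from compound 2 to compound 3 (within the scatter), within the scatter.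

Among the compounds with values here, no fluorinated compound has been measured. Within the data shown here, the only halogen-bearing aryl group so far is the 4-bromophenyl of compound 1, so a position between compound 1 and compound 3 is expected, though with little support from three compounds. The expected change in this assay is a 1.8-fold lower number from compound 3 to compound 4 (0.24 log units; within the scatter), a small drop that would probably stay within the scatter. For compound 4 the estimated clearance is 8 mL/min/kg, with an expected range of 3 mL/min/kg to 20 mL/min/kg.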

Compound 4, clearance: 12 mL/min/kg
For compound 4 the middle estimate is 1.5-fold (0.18 log units) below the measured one; the range from low to high includes it.
By their numbers in this assay, from the lowest: compound 1; then compounds 4, 2 and 3 (each within the scatter of the next).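

In this assay the 2,4-difluorophenyl group on this amide-type nitrogen falls in with the 3-methoxyphenyl and 3-methylphenyl groups: the steps read a 1.2-fold lower number from compound 3 to compound 4 (0.07 log units; within the scatter) and a 1.2-fold lower number from compound 2 to compound 4 (0.07 log units; within the scatter) while the 4-bromophenyl group stays apart with a 4.0-fold higher number from compound 1 to compound 4 (0.60 log units; beyond the scatter) as its step. Compound 1 thus remains the only one of the four set apart by steps beyond the scatter, and a halogen on this aryl group does not by itself go with the low number, since compound 4 carries fluorine and compound 1 bromine. No measurement at hand speaks to why the 4-bromophenyl group alone stands apart.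

Still open, on these data alone, is whether the low number of compound 1 belongs to bromine as such or to the 4-bromophenyl group as a whole, a question that a phenyl group bearing chlorine or trifluoromethyl on this nitrogen would begin to separate. Also open, as far as these compounds go, is how a phenyl group carrying an amine or a carboxylic acid, or a pyridine ring in place of the phenyl, would read here on the shared core.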